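This account rests on a few compounds, and the source may have more. Where it says the series, first, only, none or still open, it means among the compounds named here.

Compound 2 `CC[S+]([O-])CCCCN=C=S` stands lowest of the two measured compounds in a functional assay on HepG2 cells (Homo sapiens) for cytotoxicity, read by MTT assay, with a stated time of 72 h (on this read-out higher numbers stand for weaker inhibition and lower numbers for stronger inhibition), at 5350 nM while compound 1 `S=C=NCCCCSCc1ccccc1` reads 12600 nM on the higher side, a gap beyond the usual scatter. Compound 3 `CCC[S+]([O-])CCCCN=C=S` differs from compound 2 by one change (methyl in place of hydrogen on a saturated chain carbon, two bonds along the chain from a sulfur): methyl in place of hydrogen on a saturated chain carbon, two bonds along the chain from a sulfur, which turns ethyl into propyl. Among the measured compounds shown here, no measured step in this assay covers this change, and no shift in either direction beyond the scatter is expected. The step of a 1.1-fold lower number from compound 2 to compound 3 (0.03 log units; within the scatter) is expected to stay within the scatter. For compound 3 the expected value is 5000 nM within an estimated range (2400 nM to 10500 nM).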

Compound 3, half-maximal inhibitory concentration: 3910 nM
The estimate for compound 3 lay 1.3-fold (0.11 log units) above the measured number; the measured number falls inside the stated range.
By their numbers in this assay, from the lowest: compounds 3 and 2 (each within the scatter of the next); then compound 1.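

In this assay, among the compounds shown here, ethyl to propyl gives the first measured step at this position, a 1.4-fold lower number from compound 2 to compound 3 (0.14 log units; within the scatter), so methyl in place of hydrogen on a saturated chain carbon, two bonds along the chain from a sulfur, brings no shift beyond the scatter. At this length the read-out does not separate the two chains. No measurement shown accounts for this result.

From the compounds shown here alone, whether a longer chain such as butyl would stay within the scatter remains open. So does the effect of an amine or a carboxylic acid on this chain.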